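The compounds below may be only part of what the source reports. "The series", "measured", "known", "first", "only" and "open" are said of these compounds alone.

Measured compounds:
compound 1 `COc1cc2c(Oc3ccc(NC(=O)Nc4ccccc4Cl)cc3)ccnc2cc1OCCCCCCC(=O)NO`, which in a functional assay on A549 cells (Homo sapiens) for antiproliferative activity, read by MTT assay (a lower number here means a stronger inhibitor, a higher number a weaker inhibitor), gives 1910 nM
compound 2 `COc1cc2c(Oc3ccc(NC(=O)Nc4ccc(Cl)c(C(F)(F)F)c4)cc3)ccnc2cc1OCCCCCCC(=O)NO`, which in this assay gives 5020 nM

Compound 2 holds the higher of the two numbers, with compound 1 below it by a 2.6-fold higher number from compound 1 to compound 2 (0.42 log units; beyond the scatter). Compound 3 `COc1ccccc1NC(=O)Nc1ccc(Oc2ccnc3cc(OCCCCCCC(=O)NO)c(OC)cc23)cc1` is not yet measured; it differs from compound 2 in one place: 2-methoxyphenyl in place of 4-chloro-3-(trifluoromethyl)phenyl on an amide-type nitrogen. For the measured compounds named here, the only measured step that bears on this swap of the aryl group on the amide-type nitrogen is a 2.6-fold higher number from compound 1 to compound 2 (0.42 log units; beyond the scatter), a modest change. A step of similar size in the opposite direction is therefore expected in this assay, taking compound 3 back toward compound 1: a 2.3-fold lower number from compound 2 to compound 3 (0.36 log units; beyond the scatter). Compound 3 is estimated at 2200 nM, within 900 nM to 5500 nM.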

Compound 3, half-maximal inhibitory concentration: 16200 nM
The estimate for compound 3 lay 7.4-fold (0.87 log units) below the measured number, and the stated range ends below it.
By their numbers in this assay, from the lowest: compound 1; then compound 2; then compound 3.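

In this assay, the step of a 3.2-fold higher number from compound 2 to compound 3 (0.51 log units; beyond the scatter) shows that the aryl group on the amide-type nitrogen can shift the number further than the earlier pair revealed. Methoxy in place of chloro on an aromatic carbon gives an 8.5-fold higher number from compound 1 to compound 3 (0.93 log units; beyond the scatter) and is the largest step seen at this position, so this single exchange matters more here than the change from 2-chlorophenyl to 4-chloro-3-(trifluoromethyl)phenyl. Nothing available explains why these numbers differ. From the compounds shown here alone, whether an amine, a carboxylic acid or a methyl group in place of that chloro would give a lower or higher number remains open.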